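A few compounds are considered here, and "the series" means these few. Any claim that something is new, unique, unknown or untested is made for them only; others in the source may bear on it.

In a functional assay on B16-F10 cells (Mus musculus) for cytotoxicity (a higher number here means a weaker inhibitor, a lower number a stronger inhibitor), compound 1 (`O=c1oc2ccccc2c2nc3c(ccc4cc[nH]c43)c(-c3ccc(O)cc3)c12`) reads 70700 nM and compound 2 (`O=c1oc2ccccc2c2nc3c(ccc4cc[nH]c43)c(-c3ccccc3Br)c12`) reads 70700 nM while compound 3 (`O=c1oc2ccccc2c2nc3c(ccc4cc[nH]c43)c(-c3ccccc3)c12`) reads 70700 nM and so stands level with both. Compound 4 (`O=c1oc2ccccc2c2nc3c(ccc4cc[nH]c43)c(-c3cccc(Cl)c3Cl)c12`) carries 2,3-dichlorophenyl in place of phenyl on an aromatic carbon. Two measured changes on the same phenyl bear on this: no change at the digits printed from compound 2 to compound 3 (within the scatter) for a bromo and no change at the digits printed from compound 1 to compound 3 (within the scatter) for a hydroxy, and no change at the digits printed from compound 1 to compound 2 (within the scatter) agrees with them. Going by the values given here, no chloro compound has been measured yet. The expected result is therefore no step beyond the scatter, and the estimated step runs a 1.1-fold lower number from compound 3 to compound 4 (0.04 log units; within the scatter) with no firm direction. Compound 4 is expected at 65000 nM within an estimated range from 30000 nM to 95000 nM in these notes.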

Compound 4, half-maximal inhibitory concentration: 70700 nM
Estimate against measurement, compound 4: 1.1-fold (0.04 log units) below; measured number inside the range.
By their numbers in this assay, from the lowest: compounds 1, 2, 3 and 4 (each within the scatter of the next).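

In this assay, 2,3-dichlorophenyl brings the first chloro groups and the first doubly substituted phenyl to this position, yet the step shows no change at the digits printed from compound 3 to compound 4 (within the scatter) and adds nothing beyond the scatter. The comparison with the earlier substituted rings gives no change at the digits printed from compound 2 to compound 4 (within the scatter) and no change at the digits printed from compound 1 to compound 4 (within the scatter) as well, so all four aryl groups at this position now read alike. No available evidence accounts for this flat reading.

Still open, going by these compounds, is whether an amine, a carboxylic acid or a longer chain on this phenyl would move the number. Changes to the shared core also remain open.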